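A few compounds are considered here, and "the series" means these few. Any claim that something is new, unique, unknown or untested is made for them only; others in the source may bear on it.

In a functional assay on brain (Rattus norvegicus, strain Wistar) for inhibition (on this read-out lower numbers stand for stronger inhibition and higher numbers for weaker inhibition), compound 2 `CCCCOc1ccc(-c2c(C)[nH]c(=O)n2C2CCCCC2)cc1` gives 13900 nM. This is level with compound 3 `CCCc1ccc(-c2c(C)[nH]c(=O)n2C2CCCCC2)cc1` at 13900 nM, while compound 1 `CCCCc1ccc(-c2c(C)[nH]c(=O)n2C2CCCCC2)cc1` gives 27100 nM, still within the scatter of both. The next compound, compound 4 `CCCCCCCCCCCCOc1ccc(-c2c(C)[nH]c(=O)n2C2CCCCC2)cc1`, carries a much longer chain on the same core: octyl in place of hydrogen on a saturated chain carbon, four bonds along the chain from an oxygen on an aromatic ring.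

Among the compounds with values here, three measured steps bear on this change. Within the data shown here, the only one that alters chain length alone is a 1.9-fold lower number from compound 1 to compound 3 (0.29 log units; within the scatter). The exchange of butyl for butoxy gives a 1.9-fold lower number from compound 1 to compound 2 (0.29 log units; within the scatter), and the comparison of the butoxy and propyl compounds gives no change at the digits printed from compound 2 to compound 3 (within the scatter). None of these steps goes beyond the scatter, but all of them are small edits, and none comes close to an addition of this length. Among the measured compounds shown here, they therefore offer no firm direction, and the data hold no compound with a chain longer than butoxy. The estimated step, a 1.3-fold lower number from compound 2 to compound 4 (0.10 log units; within the scatter), is expected to stay within the scatter, with real uncertainty on either side. For compound 4 the expected value in this assay is 11000 nM, with an estimated range from 2800 nM to 42000 nM.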

Compound 4, half-maximal inhibitory concentration: 52400 nM
Estimate against measurement, compound 4: 4.8-fold (0.68 log units) below; the whole stated range lies below it.
By their numbers in this assay, from the lowest: compounds 2, 3, 1 and 4 (each within the scatter of the next, the first and the last beyond it).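

In this assay the addition of octyl on a saturated chain carbon, four bonds along the chain from an oxygen on an aromatic ring, gives a 3.8-fold higher number from compound 2 to compound 4 (0.58 log units; beyond the scatter) and is the first step among these compounds to go beyond the scatter, in the direction of weaker inhibition. The earlier edits at this end of the molecule, from butyl to butoxy and to propyl, all stayed within the scatter, so they gave no sign that a change here could move the number by a readable amount; compound 4 shows that this position does not accept an addition of this length without a cost. Nothing in the data shown accounts for this loss.

What the compounds leave open is how the number behaves between the two chain lengths, since a single long chain cannot show whether ethyl or butyl on that same carbon would already raise it or whether the rise sets in only with a longer chain. As far as these compounds go, it also remains open whether an amine or a carboxylic acid on that carbon would be met with the same loss as octyl.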